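Chlorine to Bromine: Does the Swap Hold Elsewhere?

The compounds below may be only part of what the source reports. "The series", "measured", "known", "first", "only" and "open" are said of these compounds alone.

Compound 1 `O=C(Nc1c(C(O)(C(F)(F)F)C(F)(F)F)ccc2ccccc12)c1cccc(Cl)c1`, compound 2 `O=C(Nc1c(C(O)(C(F)(F)F)C(F)(F)F)ccc2ccccc12)c1cccc(Br)c1` and compound 3 `O=C(Nc1c(C(O)(C(F)(F)F)C(F)(F)F)ccc2ccccc12)c1ccc(Cl)cc1` share one core and differ only in the halogenated phenyl ring attached to the amide carbonyl. In an assay on LtK cells with ATP-sensitive inward rectifier potassium channel 11 (Homo sapiens) as the target (a higher number here means that more compound is needed for the effect, a lower number that less compound is needed), compound 1 gives 98 nM, compound 2 gives 80 nM and compound 3 gives 570 nM. Replacing chloro by bromo, (bromo in place of chloro on an aromatic carbon), gave a 1.2-fold lower number from compound 1 to compound 2 (0.09 log units; within the scatter). Moving the chlorine within the ring, (4-chlorophenyl in place of 3-chlorophenyl on a carbonyl carbon), gave a 5.8-fold higher number from compound 1 to compound 3 (0.76 log units; beyond the scatter), and the bromo analogue shows a 7.1-fold higher number from compound 2 to compound 3 (0.85 log units; beyond the scatter).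

Compound 4 `O=C(Nc1c(C(O)(C(F)(F)F)C(F)(F)F)ccc2ccccc12)c1ccc(Br)cc1` has not yet been tested. It carries the change (bromo in place of chloro on an aromatic carbon). Among the compounds with values here, this is the same kind of change as the one between compound 1 and compound 2, but there the halogen sat meta to a large group, whereas here it sits para to a large group. Because the earlier halogen swap gave a 1.2-fold lower number from compound 1 to compound 2 (0.09 log units; within the scatter), for compound 4 a step of similar size is expected, a 1.2-fold lower number from compound 3 to compound 4 (0.08 log units; within the scatter). On that basis compound 4 is expected to give about 470 nM in this assay, plausibly between 230 nM and 950 nM.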

Compound 4, half-maximal effective concentration: 47 nM
Beside the measured number, compound 4's estimate is 10-fold (1.00 log units) above it; the whole stated range lies above it.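

The same swap of chloro for bromo gave a 12-fold lower number from compound 3 to compound 4 (1.08 log units; beyond the scatter), so the size of this step did not carry from one core to the other: the same change on two cores in this assay, a 1.2-fold lower number (0.09 log units; within the scatter) from compound 1 to compound 2 and a 12-fold lower number (1.08 log units; beyond the scatter) from compound 3 to compound 4, 9.9-fold (1.00 log units) apart, beyond the scatter of two such steps

Among the bromo compounds, 4-bromophenyl in place of 3-bromophenyl gave a 1.7-fold lower number from compound 2 to compound 4 (0.23 log units; within the scatter), and 4-bromophenyl in place of 3-chlorophenyl gave a 2.1-fold lower number from compound 1 to compound 4 (0.32 log units; beyond the scatter), which leaves compound 3 as the one that stands apart from the other three in this assay. These two chloro-to-bromo pairs show that the swap cannot be assumed to have the same size wherever the halogen sits, but they do not show why the steps differ or how the swap would behave on any other core.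

The compounds shown leave open how a fluoro, iodo or methyl group would fare on the same phenyl ring. They also leave open whether an amine or a carboxylic acid in place of the halogen would fit the trend seen with chloro and bromo.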